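The source may hold more compounds than are shown below. What is called first, only, known or untested is meant among the compounds shown, and "the series" means these compounds.

Compound 1, `COc1ccc(CO/N=C/c2c(C)nn(C)c2Oc2ccc(Cl)cc2)cc1`: 43.9%
Compound 2, `Cc1nn(C)c(Oc2ccccc2)c1/C=N/OCc1ccc([N+](=O)[O-])cc1`: 39.4%

Of the compounds shown here, two have so far been measured in a functional assay on A549 cells (Homo sapiens) for antiproliferative activity, tested at 1 uM; a higher number here means more inhibition at the concentration tested (going by the name of the read-out), a lower number less inhibition. Compound 1 gives 43.9%, the higher of the two numbers, while compound 2 gives 39.4%; the two values lie within the scatter of each other, so no order between them can be drawn. Both carry the same core and the same oxime ether link to a substituted benzyl group, and differ from each other at two places at once.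

Compound 3, `COC(=O)c1ccc(CO/N=C/c2c(C)nn(C)c2Oc2ccc(Cl)cc2)cc1`, has not yet been measured in this assay. It differs from compound 1 as follows: methoxycarbonyl in place of methoxy on an aromatic carbon. For the measured compounds named here, no pair of measured compounds that differ in a single place has been recorded, so there is no precedent in these data for the size of such a change. What the two measured values do show is that altering the benzyl substituent, together with a second change, left the read-out within the scatter.

On that basis compound 3 is expected to behave much like compound 1, with a step of a number 3.9 percentage points lower from compound 1 to compound 3 (within the scatter) no larger than the scatter. The estimate for compound 3 is 40%, with a range from 25% to 55%.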

Compound 3, a percentage reported as inhibition, at one concentration (the size of the read-out at that concentration, not a potency): 49.9%
For compound 3 the middle estimate is 9.9 percentage points below the measured one; low and high end bracket the measured number.
By their numbers in this assay, from the lowest: compounds 2, 1 and 3 (each within the scatter of the next, the first and the last beyond it).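

For the compounds shown here, this is the first step that differs in one place only: in this assay, methoxycarbonyl in place of methoxy on an aromatic carbon, para to a large group, gives a number 6 percentage points higher from compound 1 to compound 3 (within the scatter). Compounds 1 and 2 could not show this, as they differ at two places at once, so their closeness said nothing about this position alone. Here the larger methoxycarbonyl group, with its double bond outside aromatic rings, stands on the same carbon as methoxy and leaves the read-out within the scatter, and nothing available accounts for this result or says whether the two groups act alike.

Whether a carboxylic acid, an amine or a longer chain on this aromatic carbon would give a step beyond the scatter remains open, so the compounds shown do not establish that this position can move the read-out at all. The separate contribution of the chlorine on the other aromatic ring also remains open, as no pair shown differs at that place alone.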